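Oral exposure in rats: three measured, one pending

The compounds below may be only part of what the source reports. "The series", "measured", "known", "first", "only" and "open" are said of these compounds alone.

compound 1, `Cc1nc(NC(C)C)nc(N[C@@H]2C[C@H](CO)[C@@H](O)[C@H]2O)c1-c1nc2ccccc2s1`: 8420 ng.h/mL
compound 2, `Cc1nc(NCCC(F)(F)F)nc(N[C@@H]2C[C@H](CO)[C@@H](O)[C@H]2O)c1-c1nc2ccccc2s1`: 2560 ng.h/mL
compound 3, `Cc1nc(NCc2cccs2)nc(N[C@@H]2C[C@H](CO)[C@@H](O)[C@H]2O)c1-c1nc2ccccc2s1`: 242 ng.h/mL

These numbers come from an ADME assay on the whole organism (plasma) for pharmacokinetics, with Rattus norvegicus as the target, with a stated time of 6 h, at a dose of 10 mg/kg by the oral route; a lower number here means less compound in the circulation, a higher number more compound in the circulation at the dose given. Compound 3 stands lowest of the three, as a 35-fold lower number from compound 1 to compound 3 (1.54 log units; beyond the scatter) and an 11-fold lower number from compound 2 to compound 3 (1.02 log units; beyond the scatter) show, both beyond the scatter. Compound 4, `Cc1nc(NCc2ccncc2)nc(N[C@@H]2C[C@H](CO)[C@@H](O)[C@H]2O)c1-c1nc2ccccc2s1`, is not yet measured and differs from compound 3 in one place: pyridin-4-yl in place of thiophen-2-yl on a saturated chain carbon bound to a nitrogen on an aromatic ring. Among the compounds with values here, no measured step exchanges one aromatic ring for another at this position; the steps that bear on it, a 35-fold lower number from compound 1 to compound 3 (1.54 log units; beyond the scatter) and an 11-fold lower number from compound 2 to compound 3 (1.02 log units; beyond the scatter), both end at the thiophene-bearing compound and were large, and the change to compound 4 keeps an aromatic ring on the same chain carbon. The number is therefore expected to move only modestly: a 1.7-fold higher number from compound 3 to compound 4 (0.22 log units; within the scatter) is the expected step. Compound 4 is estimated at 400 ng.h/mL, with a range from 80 ng.h/mL to 2000 ng.h/mL.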

Compound 4, area under the concentration-time curve: 47.9 ng.h/mL
For compound 4 the middle estimate is 8.4-fold (0.92 log units) above the measured one, and the stated range ends above it.
By their numbers in this assay, from the lowest: compound 4; then compound 3; then compound 2; then compound 1.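

In this assay the exchange of one aromatic ring for another on the saturated chain carbon gives a 5.1-fold lower number from compound 3 to compound 4 (0.70 log units; beyond the scatter) and so the identity of the ring counts at this position, not merely its presence. The gaps to the groups without an aromatic ring widen to a 53-fold lower number from compound 2 to compound 4 (1.73 log units; beyond the scatter) and a 180-fold lower number from compound 1 to compound 4 (2.24 log units; beyond the scatter) and leave compound 4 lowest of the series. Nothing available here accounts for these drops.

Open, from the compounds shown here alone, is whether a phenyl ring on the same chain carbon would stand nearer compound 3 or compound 4. Also open, going by these compounds, is whether pyridin-3-yl would follow pyridin-4-yl.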